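This account rests on a few compounds, and the source may have more. Where it says the series, first, only, none or still open, it means among the compounds named here.

Measured so far in an ADME assay on HEK293 cells (Homo sapiens) for cytotoxicity, read by sulforhodamine B assay, with a stated time of 48 h, tested at 10 uM; a higher number here means more inhibition at the concentration tested (going by the name of the read-out), a lower number less inhibition:
- compound 1 `COc1nc2ccc(Br)cc2cc1C(c1ccccc1)n1cc(C2CC2)nn1` gives 8.22%
- compound 2 `COc1nc2ccc(Br)cc2cc1C(c1ccccc1)n1cc(-c2cccc(F)c2)nn1` gives 6.84%
- compound 3 `COc1nc2ccc(Br)cc2cc1C(c1ccccc1)n1cc(-c2ccccc2)nn1` gives 8.25%

Compound 2 stands at the low end of these three numbers, but the gap to compound 1, a number 1.4 percentage points lower from compound 1 to compound 2 (within the scatter), and the gap to compound 3, a number 1.4 percentage points higher from compound 2 to compound 3 (within the scatter), both lie within the scatter, so the three compounds are not separated by this assay. The third pairing, a number 0 percentage points higher from compound 1 to compound 3 (within the scatter), is likewise within the scatter: swapping cyclopropyl for phenyl on the shared core changed nothing that can be read.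

The next compound, compound 4 `COc1nc2ccc(Br)cc2cc1C(c1ccccc1)n1cc(-c2ccccc2C(F)(F)F)nn1`, is reached from compound 2 by 2-(trifluoromethyl)phenyl in place of 3-fluorophenyl on an aromatic carbon.

Among the compounds with values here, the steps that bear on it are the two that alter the same aromatic carbon: the cyclopropyl-to-aryl steps and the fluoro-to-hydrogen step, all of which were flat. Within the data shown here, no measured step on this series has moved the read-out beyond the scatter, and nothing in the data distinguishes a 2-(trifluoromethyl)phenyl from the aryl groups already tried. The expectation for the step to compound 4 is therefore no change beyond the scatter, a number 0.7 percentage points higher from compound 2 to compound 4 (within the scatter).

Compound 4 is estimated at 7.5% in this assay, with a range of -3% to 18%.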

Compound 4, a percentage reported as inhibition, at one concentration (the size of the read-out at that concentration, not a potency): 14.3%
Compound 4: the middle estimate sits 6.8 percentage points below what was measured, and the stated range covers the measured number.
By their numbers in this assay, from the lowest: compounds 2, 1, 3 and 4 (each within the scatter of the next).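

Notes on the aromatic carbon of the five-membered ring with 3 nitrogen: in this assay this position now carries a 2-(trifluoromethyl)phenyl group, which has more heavy atoms than any group tried there earlier, and the exchange for 3-fluorophenyl gives (a number 7.5 percentage points higher from compound 2 to compound 4 (within the scatter)). The other two comparisons agree, with trifluoromethyl in place of hydrogen on the aryl ring giving (a number 6.1 percentage points higher from compound 3 to compound 4 (within the scatter)) and 2-(trifluoromethyl)phenyl in place of cyclopropyl giving (a number 6.1 percentage points higher from compound 1 to compound 4 (within the scatter)), so a larger, substituted aryl group at this position still does not separate the compounds, as the smaller aryl groups and cyclopropyl did not. No measurement shown offers any explanation for these numbers.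

As far as these compounds go, whether any group at this aromatic carbon can carry the number beyond the scatter remains open, for instance an aliphatic amine, a carboxylic acid or a longer alkyl chain in place of the aryl ring. All four compounds keep the same shared core, so the compounds shown also leave open how replacing its bromo or methoxy group would read in this assay.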